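The source may hold more compounds than are shown below. What is called first, only, known or untested is meant among the compounds shown, and "the series" means these compounds.

Measured so far in a functional assay on HepG2 cells (Homo sapiens) for inhibition, read by MTT assay; a lower number here means a stronger inhibitor, a higher number a weaker inhibitor
- compound 1 `COc1cc2ncnc(Nc3ccc(NC(=O)c4ccc(C)cc4)cc3)c2cc1OC` gives 25000 nM
- compound 2 `COc1cc2ncnc(Nc3ccc(NC(=O)c4c(F)cccc4F)cc3)c2cc1OC` gives 17000 nM

Among the measured compounds shown here, compound 2 has compound 1 as its only neighbour on these numbers, and the two values lie within the scatter of each other. For the measured compounds named here, compound 3 `COc1cc2ncnc(Nc3ccc(NC(=O)c4ccc(Cl)c(Cl)c4)cc3)c2cc1OC` keeps the shared core and carries 3,4-dichlorophenyl in place of 2,6-difluorophenyl on a carbonyl carbon in the same place as the one measured change. Going by the values given here, that change, a 1.5-fold lower number from compound 1 to compound 2 (0.17 log units; within the scatter) and so no real shift, is the only guide, and no measured compound carries 3,4-dichlorophenyl. On that thin basis, no step beyond the scatter is expected in this assay and no direction can be argued. The estimate means a 1.1-fold lower number from compound 2 to compound 3 (0.03 log units; within the scatter) as the expected step. Compound 3 is estimated at 16000 nM with an expected range from 6000 nM to 40000 nM for the next measurement.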

Compound 3, half-maximal inhibitory concentration: 28000 nM
Compound 3: middle estimate off by 1.8-fold (0.24 log units), on the low side; low and high end bracket the measured number.
By their numbers in this assay, from the lowest: compounds 2, 1 and 3 (each within the scatter of the next).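

Putting 3,4-dichlorophenyl on the carbonyl carbon in place of 2,6-difluorophenyl gives a 1.6-fold higher number from compound 2 to compound 3 (0.22 log units; within the scatter) in this assay, and putting it in place of 4-methylphenyl gives a 1.1-fold higher number from compound 1 to compound 3 (0.05 log units; within the scatter). With a third aryl group now read at this place, compound 1, compound 2 and compound 3 all stand within the scatter of one another, so chlorine, fluorine and methyl substitution on this phenyl ring do not separate in this assay. No measurement is at hand that bears on this result.

Open, on these data alone, is whether anything other than a substituted phenyl on this carbonyl carbon, such as a phenyl ring carrying an amine or a carboxylic acid, or a longer alkyl chain, would give a step beyond the scatter. Also open, as far as these compounds go, is whether these three compounds read alike outside this cell assay.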